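Working notes: from butylsulfanyl compound 3 to benzylsulfanyl compound 4

A few compounds are considered here, and "the series" means these few. Any claim that something is new, unique, unknown or untested is made for them only; others in the source may bear on it.

Measured compounds in an ADME assay on Akata cells (Homo sapiens) for cytotoxicity, with a stated time of 7 days; a higher number here means that more compound is tolerated, a lower number that less compound is tolerated:
Compound 1 `CC(C)CSc1nc(N)nc2c1ncn2/C=C1/CC1(CO)CO`: > 20000 nM, a limit.
Compound 2 `Nc1nc(NCc2ccccc2)c2ncn(/C=C3/CC3(CO)CO)c2n1`: > 24000 nM, a limit.
Compound 3 `CCCCSc1nc(N)nc2c1ncn2/C=C1/CC1(CO)CO`: > 20000 nM, a limit.

For the measured compounds named here, compound 3 has no number of its own, and neither does any other compound measured so far. The record consists of the limit of > 20000 nM in this assay, at which 2 of the 3 values shown sit, together with the limit of > 24000 nM in this assay, at which 1 of the 3 values shown sits.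

Compound 4 `Nc1nc(SCc2ccccc2)c2ncn(/C=C3/CC3(CO)CO)c2n1` carries phenyl in place of propyl on a saturated chain carbon bound to a sulfur. The same difference reads butylsulfanyl to benzylsulfanyl.

The closest measured change is a step that the two limits leave unreadable from compound 1 to compound 3, made on the same kind of chain carbon. Benzyl appears only in compound 2, and the exchange on the aromatic carbon gives a step that the two limits leave unreadable from compound 2 to compound 3. The remaining pair gives a step that the two limits leave unreadable from compound 1 to compound 2. None of these steps has a readable size, so no size can be carried over to this assay, and no direction can be assigned.

The expectation rests on compound 3 at > 20000 nM, which is a limit. The step expected is a number no higher from compound 3 to compound 4 (the limit leaves the size open), with compound 4 likely to report a limit as well. For compound 4 the estimated value is 20000 nM, with an expected range of 9000 nM to 30000 nM.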

Compound 4, half-maximal cytotoxic concentration: > 20000 nM
Compound 4: no number, only a limit (the forecaster's own chance of this, stated with the estimate: 75%); the middle value lies on the limit itself.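

In this assay compound 4 gives > 20000 nM, a limit, and its steps to compound 1, compound 2 and compound 3 cannot be read, as those three compounds also report only limits. The compounds shown leave open the size and direction of every change among them, with most values sitting at a single limit: the limit of > 20000 nM in this assay, at which 3 of the 4 values shown sit.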